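Pyrrolyl for nitrofuranyl on the saturated ring carbon

The source may hold more compounds than are shown below. What is called first, only, known or untested is meant among the compounds shown, and "the series" means these compounds.

Measured so far:
compound 1 `COc1ccc(Cl)c(-c2nnc3n2NC(c2ccc([N+](=O)[O-])o2)S3)c1` gives 24.2%
compound 2 `COc1ccc(Cc2nnc3n2NC(c2ccc([N+](=O)[O-])o2)S3)cc1OC` gives 23.7%
compound 3 `COc1ccc(Cl)c(-c2nnc3n2NC(c2ccc[nH]2)S3)c1` gives 20.6%

All three numbers come from a functional assay on the whole organism (strain Wistar Albino) for inhibition, with Rattus norvegicus as the target, read by paw edema, with a stated time of 4 h, at a dose of 20 mg/kg; a lower number here means less inhibition, a higher number more inhibition at the dose given (going by the name of the read-out). Compound 1 and compound 2 differ in their cores; the difference between the two cores is not broken down here. Compound 2 stands with its value near compound 1, and the gap to compound 3 is within the scatter, so no ordering among the three is drawn.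

Compound 1 and compound 3 share a core and differ in one place: 1H-pyrrol-2-yl in place of 5-nitrofuran-2-yl on a saturated ring carbon. This change gave a number 3.6 percentage points lower from compound 1 to compound 3 (within the scatter), a step that lies within the scatter, so the read-out in this assay did not move in a way that can be told from repeated measurement.

Compound 4 `COc1ccc(Cc2nnc3n2NC(c2ccc[nH]2)S3)cc1OC` is not yet measured. It stands to compound 2 as compound 3 stands to compound 1: 1H-pyrrol-2-yl in place of 5-nitrofuran-2-yl on a saturated ring carbon. The place is the same word for word in both pairs, so this is the same change made on the other core.

Resting on the step seen from compound 1 to compound 3, compound 4 is expected to lie close to compound 2, and the step from compound 2 to compound 4 in this assay is estimated as a number 3.7 percentage points lower from compound 2 to compound 4 (within the scatter). Among the measured compounds shown here, the number for compound 4 in this assay is expected to be 20%, with a range from 10% to 30% owing to the scatter of single-dose paw edema readings; the earlier step is the only guide, and the two cores may not answer the change alike.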

Compound 4, a percentage reported as inhibition, in the whole organism at one dose (the size of the read-out at that dose, not a potency): 21.5%
Estimate against measurement, compound 4: 1.5 percentage points below, and the stated range covers the measured number.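

In this assay, 1H-pyrrol-2-yl in place of 5-nitrofuran-2-yl on the saturated ring carbon gave a number 2.2 percentage points lower from compound 2 to compound 4 (within the scatter), so on this second core, too, the read-out did not move in a way that can be told from repeated measurement. Set beside the earlier step, the change carries across the two cores without a difference that can be told apart: the same change on two cores in this assay, a number 3.6 percentage points lower (within the scatter) from compound 1 to compound 3 and a number 2.2 percentage points lower (within the scatter) from compound 2 to compound 4, 1.4 percentage points apart, within the scatter of two such steps This shows only that a step within the scatter on one core was matched by a step within the scatter on the other; it does not show that the two groups are equivalent in general, that the change would behave the same way on a further core, or that the same would hold at another dose or time, since each compound is read at a single dose and time point.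

Still open, as far as these compounds go, is which part of 5-nitrofuran-2-yl matters, if any part does, as a plain furan-2-yl would separate the ring from the nitro group. Also open, from the compounds shown here alone, is whether a clearly different group on the saturated ring carbon, such as a carboxylic acid or an amine on a longer chain, would move the read-out beyond the scatter.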